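A few compounds are considered here, and "the series" means these few. Any claim that something is new, unique, unknown or untested is made for them only; others in the source may bear on it.

Measured so far:
compound 1, `O=C(/C=C1\CCc2ccc(F)cc21)NCCO`: 50%
compound 2, `O=C(/C=C1\CCc2ccc(F)cc21)N1CCC1`: 33%

In a functional assay on the whole organism with Mus musculus as the target, at a dose of 100 mg/kg by the intraperitoneal route (a lower number here means less inhibition, a higher number more inhibition at the dose given (going by the name of the read-out)), compound 2 stands at the lower of the two numbers, with compound 1 giving 50% above it. Within the data shown here, the only measured step, a number 17 percentage points lower from compound 1 to compound 2 (beyond the scatter), moved from a chain amine bearing one hydrogen-bond donor to a ring with none. Compound 3, `CCCNC(=O)/C=C1\CCc2ccc(F)cc21`, differs from compound 2 by propylamino in place of azetidin-1-yl on a carbonyl carbon. This restores a chain amine with one hydrogen-bond donor, though without the hydroxyl of compound 1, so a partial recovery is expected, estimated as a number 11 percentage points higher from compound 2 to compound 3 (beyond the scatter). Compound 3 is therefore expected to give about 44%, within 25% to 63%.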

Compound 3, a percentage reported as inhibition, in the whole organism at one dose (the size of the read-out at that dose, not a potency): 100%
For compound 3 the middle estimate is 56 percentage points below the measured one; the measured number lies above the stated range.
By their numbers in this assay, from the lowest: compound 2; then compound 1; then compound 3.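

In this assay, propylamino in place of azetidin-1-yl on the carbonyl carbon gives a number 67 percentage points higher from compound 2 to compound 3 (beyond the scatter), so an open chain with an amide hydrogen can do far better than the ring of the same heavy-atom count. The hydroxy of compound 1 proves unnecessary here, as methyl in its place gives a number 50 percentage points higher from compound 1 to compound 3 (beyond the scatter). Nothing measured explains either step. The ring-to-chain step removes the ring and adds the amide hydrogen together, so their separate contributions stay unresolved. From the compounds shown here alone, whether a longer chain, such as butylamino, or a terminal amine would hold this level also remains open.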